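The source may report more compounds than this note shows. Statements on the series, on what has been measured and on what is new or still open speak of the compounds shown alone.

Compound 2 `O=C(Nc1ccc(C(F)(F)F)cc1)c1csc(Cc2c(Cl)cccc2Cl)n1` is the anchor of this comparison. In an assay on CHO cells, read by calcium flux (on this read-out lower numbers stand for stronger inhibition and higher numbers for weaker inhibition), compound 2 gives 140 nM, the lowest of the two actual numbers. Compound 1 `CC(C)c1ccc(NC(=O)c2csc(Cc3c(Cl)cccc3Cl)n2)cc1` carries an isopropyl where compound 2 carries a trifluoromethyl; in this assay compound 1 gives 370 nM, and the change is a 2.6-fold lower number from compound 1 to compound 2 (0.42 log units; beyond the scatter). Compound 3 `O=C(Nc1ccc(C(F)(F)F)cc1)c1csc(CCc2c(Cl)cccc2Cl)n1` returns only a limit of this assay, > 4000 nM. Moving from compound 2 to compound 3, the step is an at least 28-fold higher number from compound 2 to compound 3 (1.45 log units; beyond the scatter), which stands at the limit of > 4000 nM in this assay, at which 1 of the 3 values shown sits.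

Compound 4 `Cc1cccc(C)c1Nc1nc(C(=O)Nc2ccc(C(F)(F)F)cc2)cs1` is not yet measured. It differs from compound 2 by (2,6-dimethylphenyl)amino in place of 2,6-dichlorobenzyl on an aromatic carbon. Going by the values given here, the only measured step touching this side of the shared core is an at least 28-fold higher number from compound 2 to compound 3 (1.45 log units; beyond the scatter), a large loss when the link to the dichlorinated ring was lengthened. Compound 4 instead swaps the link atom and the ring substituents, so a weakening of modest size is expected rather than a collapse. Compound 4 is therefore estimated at 600 nM, between 150 nM and 3000 nM, an expected step of a 4.3-fold higher number from compound 2 to compound 4 (0.63 log units; beyond the scatter).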

Compound 4, half-maximal inhibitory concentration: 90 nM
Estimate against measurement, compound 4: 6.7-fold (0.82 log units) above; the whole stated range lies above it.
By their numbers in this assay, from the lowest: compounds 4 and 2 (each within the scatter of the next); then compound 1. At a limit, above all of these: compound 3.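

In this assay, the change on the aromatic carbon next to the ring nitrogen and the ring sulfur leaves no difference that can be read: a 1.6-fold lower number from compound 2 to compound 4 (0.19 log units; within the scatter). Going by these compounds alone, the position therefore accepts (2,6-dimethylphenyl)amino, which brings a nitrogen link, a hydrogen-bond donor and methyl groups, whereas the earlier compounds showed a change on this side only through compound 3, which stands at a limit: the limit of > 4000 nM in this assay, at which 1 of the 4 values shown sits. Nothing measured here explains why compound 4 holds up so well.

As far as these compounds go, this change replaces the link and the ring substituents at once, so the contribution of each remains open. A (2,6-dichlorophenyl)amino group, which keeps the chlorines on a nitrogen link, or a 2,6-dimethylbenzyl group, which keeps the methyls on a carbon link, would separate the two.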